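This account rests on a few compounds, and the source may have more. Where it says the series, first, only, none or still open, it means among the compounds named here.

In a functional assay on RS4-11 cells (Homo sapiens) for inhibition, read by CCK-8 assay, with a stated time of 48 h, tested at 20 uM (on this read-out higher numbers stand for more inhibition of growth at the one concentration tested and lower numbers for less inhibition of growth), compound 1 `N#C/C(=C\c1ccccc1OS(=O)(=O)c1ccc(F)cc1)C(=O)Nc1nnc(Cc2ccccc2)s1` gives 69% and compound 2 `N#C/C(=C\c1ccccc1OS(=O)(=O)c1ccccc1[N+](=O)[O-])C(=O)Nc1nnc(Cc2cccc(F)c2)s1` gives 68%, while compound 3 `N#C/C(=C\c1ccccc1OS(=O)(=O)c1ccc(F)cc1)C(=O)Nc1nnc(Cc2cccc(F)c2)s1` gives 72% and so sits within the scatter of both. Compound 4 `N#C/C(=C\c1ccccc1OS(=O)(=O)c1ccc(F)cc1)C(=O)Nc1nnc(Cc2ccc(Cl)cc2)s1`, not yet measured, carries 4-chlorophenyl in place of 3-fluorophenyl on a saturated chain carbon bound to an aromatic carbon. The closest measured step, fluoro in place of hydrogen on an aromatic carbon, is a number 3 percentage points higher from compound 1 to compound 3 (within the scatter) and 4-fluorophenyl in place of 2-nitrophenyl on a sulfonyl sulfur is a number 4 percentage points higher from compound 2 to compound 3 (within the scatter) and neither lies beyond the scatter. Within the data shown here, no chloro compound has been measured, so the evidence is thin. The expected step is a number 2 percentage points lower from compound 3 to compound 4 (within the scatter) and nothing beyond the scatter is expected. Compound 4 is estimated at 70% with an expected range of 60% to 79% in this assay for now.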

Compound 4, percent growth inhibition at one concentration: 64%
Estimate against measurement, compound 4: 6 percentage points above; the measured number falls inside the stated range.
By their numbers in this assay, from the lowest: compounds 4, 2, 1 and 3 (each within the scatter of the next).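

In this assay the first chloro compound gives a number 8 percentage points lower from compound 3 to compound 4 (within the scatter) and, against the unsubstituted ring, a number 5 percentage points lower from compound 1 to compound 4 (within the scatter). On a saturated chain carbon bound to an aromatic carbon, 3-fluorophenyl, 4-chlorophenyl and the unsubstituted phenyl ring therefore all lie within the scatter of one another. No data on hand speak to a cause for these steps.

The step from 3-fluorophenyl to 4-chlorophenyl alters both the halogen and its place on the ring, and these two changes remain unseparated. On these data alone, whether 3-chlorophenyl, an amine or a carboxylic acid on this ring, or a longer chain would move the number beyond the scatter remains open.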